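This account rests on a few compounds, and the source may have more. Where it says the series, first, only, none or still open, it means among the compounds named here.

Compound 2 `COc1cccc(C(=O)O[C@@H]2CO[C@H]3[C@@H]2OC[C@@H]3OC(=O)c2ccccc2OC(C)=O)c1` gives 0.0142 h in an ADME assay on a cell-free system (plasma, Homo sapiens) for metabolic stability, with Plasma (Rattus norvegicus) as the target, read by HPLC, at pH 7.4 (a higher number here means that the compound lasts longer, a lower number that the compound disappears faster), and so far stands highest of the two numbers, yet only by a 1.5-fold higher number from compound 1 to compound 2 (0.17 log units; within the scatter) over compound 1 `CC(=O)Oc1ccccc1C(=O)O[C@H]1CO[C@H]2[C@@H]1OC[C@H]2OC(C)=O`, which gives 0.0095 h. Compound 3 `CC(=O)Oc1ccccc1C(=O)O[C@H]1CO[C@H]2[C@@H]1OC[C@H]2OC(=O)c1cc(C)nc(Cl)c1` differs from compound 2 by 2-chloro-6-methylpyridin-4-yl in place of 3-methoxyphenyl on a carbonyl carbon. Going by the values given here, no measured step swaps one aryl for another on this carbonyl carbon; the sole step at hand concerns a different change and lies within the scatter, so no step beyond the scatter is expected in this assay. For compound 3 the value is estimated at 0.013 h, within 0.005 h to 0.035 h, an expected step of a 1.1-fold lower number from compound 2 to compound 3 (0.04 log units; within the scatter).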

Compound 3, half-life: 0.0193 h
Compound 3: the middle estimate sits 1.5-fold (0.17 log units) below what was measured, and the stated range covers the measured number.
By their numbers in this assay, from the lowest: compounds 1, 2 and 3 (each within the scatter of the next, the first and the last beyond it).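

On this carbonyl carbon in this assay, 3-methoxyphenyl and 2-chloro-6-methylpyridin-4-yl give numbers within the scatter of each other (a 1.4-fold higher number from compound 2 to compound 3 (0.13 log units; within the scatter)). Set against methyl, 2-chloro-6-methylpyridin-4-yl gives the first step beyond the scatter, though a modest one (a 2.0-fold higher number from compound 1 to compound 3 (0.31 log units; beyond the scatter)), which 3-methoxyphenyl did not give. No measurement at hand accounts for either step.

Open, on these data alone, is whether a longer chain or a cyclohexyl group on this carbonyl carbon reads like methyl or like the two aromatic groups.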